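The source may hold more compounds than are shown below. What is called first, only, known or untested is meant among the compounds shown, and "the series" means these compounds.

Series notes. In a functional assay, with a stated time of 20 min, tested at 0.1 mM (a lower number here means a weaker effect, a higher number a stronger effect of the compound at the concentration tested), compound 1 `NCCNC(=O)c1c(O)c2ccccc2n(-c2ccccc2)c1=O` gives 7.2%. Compound 3 `O=C(CCCCC1CCSS1)NCCNC(=O)c1c(O)c2ccccc2n(-c2ccccc2)c1=O` differs from compound 1 by a group of 11 heavy atoms (8 carbon, 1 oxygen, 2 sulfur; one five-membered non-aromatic ring with 2 hetero atoms) in place of a hydrogen atom, on an amine nitrogen; in this assay compound 3 gives 6.4%. The step between them is a number 0.8 percentage points lower from compound 1 to compound 3 (within the scatter), a difference that stays inside the usual scatter of repeated measurements, so the two numbers cannot be told apart.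

Compound 2 `Cn1c(=O)c(C(=O)NCCCCCCN)c(O)c2ccccc21` is built on a different core; how the cores of compound 1 and compound 2 differ is not broken down here. In this assay compound 2 gives 3.1%, a number that lies within the scatter of the values for compound 1 and compound 3, so all three measured compounds show only a weak effect at the tested concentration.

Compound 4 `Cn1c(=O)c(C(=O)NCCCCCCNC(=O)CCCCC2CCSS2)c(O)c2ccccc21` has not yet been measured. Relative to compound 2 it carries a group of 11 heavy atoms (8 carbon, 1 oxygen, 2 sulfur; one five-membered non-aromatic ring with 2 hetero atoms) in place of a hydrogen atom, on an amine nitrogen. This is the same change as that from compound 1 to compound 3, now made on the core of compound 2, and it occurs twice among the compounds shown. Because a number 0.8 percentage points lower from compound 1 to compound 3 (within the scatter) left the number essentially unchanged on the first core, the same change on the second core is expected to leave it essentially unchanged too; the expected step in this assay is a number 0.1 percentage points lower from compound 2 to compound 4 (within the scatter). The expectation rests on a single measured pair, so it is only weakly founded. Compound 4 is expected to give 3% in this assay, with the estimate likely lying between 0% and 12%.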

Compound 4, a percentage reported as activity, at one concentration (the size of the read-out at that concentration, not a potency): 9.1%
The estimate for compound 4 lay 6.1 percentage points below the measured number; low and high end bracket the measured number.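

In this assay the new step reads a number 6 percentage points higher from compound 2 to compound 4 (within the scatter), so on this second core the group of 11 heavy atoms on the amine nitrogen gives a number that cannot be told apart from that of the parent amine. Set beside the earlier step, the two steps cannot be told apart from each other either: the same change on two cores in this assay, a number 0.8 percentage points lower (within the scatter) from compound 1 to compound 3 and a number 6 percentage points higher (within the scatter) from compound 2 to compound 4, 6.8 percentage points apart, within the scatter of two such steps. Going by these compounds alone, this shows that, at the single tested concentration, the change has no readable effect on either core and that the two cores do not separate in how they take it; it does not show that a step of a defined size carries from one core to the other, as only two pairs exist and neither step rises out of the scatter.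

The compounds shown leave open whether any other group on the same amine nitrogen, such as a plain acetyl or a chain ending in a carboxylic acid, would move the read-out beyond the scatter. They also leave open what a single change to the chain linking the amide to the amine, or to the substituent on the ring nitrogen, would do on its own, as compound 1 and compound 2 differ in more than one place.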